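The source may hold more compounds than are shown below. What is called first, only, known or untested is meant among the compounds shown, and "the series" means these compounds.

Compound 1 `COc1cc(/C=N/NC(=O)c2nn(-c3ccc(F)c(Cl)c3)c(-c3ccc(Cl)cc3)c2C)ccc1O`: 3560000 nM
Compound 2 `COc1cc(/C=N/NC(=O)c2nn(-c3ccc(F)cc3F)c(-c3ccc(F)cc3)c2C)ccc1O`: 3540000 nM

In a physicochemical assay (a lower number here means that less compound is needed, a higher number that more compound is needed for the effect), compound 2 gives 3540000 nM and stands level with compound 1 at 3560000 nM, as the two numbers lie within the usual scatter of each other.

Compound 3 `COc1cc(/C=N/NC(=O)c2nn(-c3ccc(F)c(Cl)c3)c(-c3ccc(F)cc3)c2C)ccc1O` differs from compound 2 in one place, on an aromatic nitrogen of a five-membered aromatic ring with 2 nitrogen, where 3-chloro-4-fluorophenyl takes the place of 2,4-difluorophenyl (3-chloro-4-fluorophenyl in place of 2,4-difluorophenyl on an aromatic nitrogen).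

For the measured compounds named here, no two measured compounds differ in only one place, so the data hold no direct measure of this change. Going by the values given here, compound 1 already carries 3-chloro-4-fluorophenyl on that nitrogen and gives 3560000 nM, a number within the scatter of the one for compound 2. No shift beyond the scatter is therefore expected in this assay, in either direction. The expected change is a 1.0-fold higher number from compound 2 to compound 3 (0.00 log units; within the scatter). For compound 3 the estimated value is 3550000 nM, with an expected range from 2300000 nM to 5500000 nM.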

Compound 3, half-maximal effective concentration: 6920000 nM
Beside the measured number, compound 3's estimate is 1.9-fold (0.29 log units) below it, outside the stated range (above it).
By their numbers in this assay, from the lowest: compounds 2, 1 and 3 (each within the scatter of the next).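

In this assay, for the compounds shown here, putting 3-chloro-4-fluorophenyl in place of 2,4-difluorophenyl on the aromatic nitrogen gives a 2.0-fold higher number from compound 2 to compound 3 (0.29 log units; within the scatter), the first direct reading of this change, and it shows that the exchange does not move the number beyond the scatter. Fluoro in place of chloro on an aromatic carbon gives a 1.9-fold higher number from compound 1 to compound 3 (0.29 log units; within the scatter), so this second single exchange also leaves the compounds inseparable in this assay. No measurement here bears on why these numbers lie as they do.

From the compounds shown here alone, all three compounds differ only in the halogens on their phenyl groups, so how this position responds to anything else remains open. An amine, a carboxylic acid or a longer alkyl chain on that nitrogen might shift the number beyond the scatter or might not, and these compounds cannot say which.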